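Changing the Sulfonamide Aryl Group: From Nitrophenyl to Chlorophenyl

The compounds below may be only part of what the source reports. "The series", "measured", "known", "first", "only" and "open" are said of these compounds alone.

Of the compounds shown here, three sharing one core have been measured in an assay on MDA-MB-231 cells for binding affinity to C-X-C chemokine receptor type 4 (Homo sapiens), read by fluorescence and microscopy, with stated times of 10 min and 30 min; on this read-out lower numbers stand for an effect already at smaller amounts and higher numbers for an effect only at larger amounts of compound. Compound 1 `CCN(CC)Cc1ccc(S(=O)(=O)NCc2ccc(CNC(=O)c3ccc(F)cc3)cc2)cc1` gives 1 nM. Compound 2 `O=C(NCc1ccc(CNS(=O)(=O)c2ccc(-c3ccc(F)cc3)cc2)cc1)c1ccc(F)cc1` gives 100 nM. Compound 3 `O=C(NCc1ccc(CNS(=O)(=O)c2ccc([N+](=O)[O-])cc2)cc1)c1ccc(F)cc1` gives 1000 nM, the highest of the three numbers; the steps of a 1000-fold higher number from compound 1 to compound 3 (3.00 log units; beyond the scatter) and a 10-fold higher number from compound 2 to compound 3 (1.00 log units; beyond the scatter) place it well beyond the scatter from both others.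

Compound 4 `O=C(NCc1ccc(CNS(=O)(=O)c2cccc(Cl)c2)cc1)c1ccc(F)cc1` has not yet been measured. It differs from compound 3 by 3-chlorophenyl in place of 4-nitrophenyl on a sulfonyl sulfur.

For the measured compounds named here, no measured step introduces a 3-chlorophenyl group, so there is no direct precedent. What the measured steps do show is that arriving at the 4-nitrophenyl group from another group raised the number in both cases, by a large amount in a 1000-fold higher number from compound 1 to compound 3 (3.00 log units; beyond the scatter) and by a modest amount in a 10-fold higher number from compound 2 to compound 3 (1.00 log units; beyond the scatter). Leaving the 4-nitrophenyl group for a 3-chlorophenyl group is therefore expected to lower the number, by a step near a 3.3-fold lower number from compound 3 to compound 4 (0.52 log units; beyond the scatter), though with wide uncertainty. Compound 4 is estimated at 300 nM, within a range from 30 nM to 3000 nM.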

Compound 4, effective concentration (reported as EC, without a stated level of effect): 1 nM
For compound 4 the middle estimate is 300-fold (2.48 log units) above the measured one; measured number below the stated range.
By their numbers in this assay, from the lowest: compounds 1 and 4 (each within the scatter of the next); then compound 2; then compound 3.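

Exchanging 4-nitrophenyl for 3-chlorophenyl on the sulfonyl sulfur gives a 1000-fold lower number from compound 3 to compound 4 (3.00 log units; beyond the scatter) so a swap between two single aromatic rings can by itself span the whole range of numbers seen so far. Compound 1 gives (1 nM) and compound 4 gives (1 nM), so the (diethylamino)methyl group of compound 1 is not required for a number this low: the 3-chlorophenyl group holds no amine and reaches the same printed value. Nothing measured here gives a reason for a step of this size.

As far as these compounds go, it remains open whether the chlorine atom itself matters, a question that a plain phenyl group, or a bromine atom or methyl group in its place, would address. Also open, from the compounds shown here alone, is what a 3-chlorophenyl group that also carries a (diethylamino)methyl group would give.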